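Pyridazinyl in Place of Phenyl in a Receptor Agonist

The source may hold more compounds than are shown below. What is called first, only, known or untested is meant among the compounds shown, and "the series" means these compounds.

Among the compounds with values here, compound 1 `CC(C)(C)OC(=O)N1CCC(O[C@H]2CC[C@H](Oc3ccc(S(C)(=O)=O)cc3)CC2)CC1` is one of only two compounds measured here. In a functional assay on isolated protein for agonist activity at Glucose-dependent insulinotropic receptor (Rattus norvegicus), read by HTRF and cAMP accumulation (on this read-out higher numbers stand for an effect only at larger amounts of compound and lower numbers for an effect already at smaller amounts), compound 1 gives 94 nM. Within the data shown here, its sole neighbour, compound 2 `CC(C)(C)OC(=O)N1CCC(O[C@H]2CC[C@H](Oc3ccc(S(C)(=O)=O)c(F)c3)CC2)CC1`, gives 167 nM in this assay, and the single step from one to the other, a 1.8-fold higher number from compound 1 to compound 2 (0.25 log units; within the scatter), does not separate the pair. Compound 3 `CC(C)(C)OC(=O)N1CCC(O[C@H]2CC[C@H](Oc3ccc(S(C)(=O)=O)nn3)CC2)CC1` has not been measured; it differs from compound 1 in that (6-(methylsulfonyl)pyridazin-3-yl in place of 4-(methylsulfonyl)phenyl on an oxygen on a saturated carbon). Among the measured compounds shown here, no measured step bears directly on this exchange of one aromatic ring for another, since the only step on record, a 1.8-fold higher number from compound 1 to compound 2 (0.25 log units; within the scatter), concerns a fluoro substituent and stays within the scatter. Without a guiding precedent, the ring exchange is expected to give a 1.7-fold higher number from compound 1 to compound 3 (0.23 log units; within the scatter), with no firm direction. Compound 3 is therefore estimated at 160 nM in this assay, within a range from 40 nM to 650 nM.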

Compound 3, half-maximal effective concentration: 1160 nM
Beside the measured number, compound 3's estimate is 7.3-fold (0.86 log units) below it; the whole stated range lies below it.
By their numbers in this assay, from the lowest: compounds 1 and 2 (each within the scatter of the next); then compound 3.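

At the place on an oxygen on a saturated carbon, the identity of the aromatic ring matters in this assay: 6-(methylsulfonyl)pyridazin-3-yl in place of 4-(methylsulfonyl)phenyl gives a 12-fold higher number from compound 1 to compound 3 (1.09 log units; beyond the scatter). Within the data shown here, the earlier change on the aromatic ring, a 1.8-fold higher number from compound 1 to compound 2 (0.25 log units; within the scatter), did not separate its pair, so this ring exchange is the first change here to move the number beyond the scatter. Nothing at hand accounts for the size of this step.

As far as these compounds go, it remains open whether a pyridinyl or a pyrimidinyl ring in the same place would stand nearer to compound 1 or to compound 3. Also open, from the compounds shown here alone, is whether the pyridazinyl ring would give a different number with a nitrile or a carboxamide in place of the methylsulfonyl group.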